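A few compounds are considered here, and "the series" means these few. Any claim that something is new, unique, unknown or untested is made for them only; others in the source may bear on it.

Compound 1 `Cc1ccc(N(CCN2CCC(OCC(=O)O)CC2)C(=O)c2ccc(C(F)(F)F)cc2)cc1` and compound 2 `Cc1ccc(N(CCN2CCC(OCC(=O)O)CC2)C(=O)c2cccc(F)c2)cc1` share one core and differ in a single group: 3-fluorophenyl in place of 4-(trifluoromethyl)phenyl on a carbonyl carbon. In a functional assay on a cell-free system (Platelet, plasma, Homo sapiens) for inhibition (a lower number here means a stronger inhibitor, a higher number a weaker inhibitor), compound 1 gives only the assay's limit, > 10000 nM. Compound 2 in this assay gives 160 nM. Between them stands an at least 62-fold lower number from compound 1 to compound 2 (1.79 log units; beyond the scatter), readable only in part because compound 1 sits at the limit of > 10000 nM in this assay, at which 2 of the 3 values shown sit. Compound 3 `O=C(O)COC1CCN(CCN(C(=O)c2ccc(C(F)(F)F)cc2)c2ccc(Cl)cc2)CC1` carries a changed core: chloro in place of methyl on an aromatic carbon. In this assay compound 3 also gives only a limit, > 10000 nM. The step that the two limits leave unreadable from compound 1 to compound 3 follows from these two limits. Compound 4 `O=C(O)COC1CCN(CCN(C(=O)c2cccc(F)c2)c2ccc(Cl)cc2)CC1` is made from compound 3 by the same change as before: 3-fluorophenyl in place of 4-(trifluoromethyl)phenyl on a carbonyl carbon. Since compound 2 gives 160 nM, the step here is expected to be an at least 50-fold lower number from compound 3 to compound 4 (1.69 log units; beyond the scatter). Compound 4 is therefore estimated at 200 nM in this assay, with a likely range from 60 nM to 800 nM.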

Compound 4, half-maximal inhibitory concentration: 340 nM
For compound 4 the middle estimate is 1.7-fold (0.23 log units) below the measured one; measured number inside the range.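

Replacing 4-(trifluoromethyl)phenyl with 3-fluorophenyl on a carbonyl carbon also brings a large change on the chloro-bearing core in this assay, with an at least 29-fold lower number from compound 3 to compound 4 (1.46 log units; beyond the scatter), so the direction of the step carries from one core to the other. This does not show that the step keeps its size: (the same change on two cores in this assay, an at least 62-fold lower number (1.79 log units; beyond the scatter) from compound 1 to compound 2 and an at least 29-fold lower number (1.46 log units; beyond the scatter) from compound 3 to compound 4; the limit leaves it open whether they differ). With 3-fluorophenyl in place, swapping methyl for chloro has a modest effect, with a 2.1-fold higher number from compound 2 to compound 4 (0.33 log units; beyond the scatter), while the step between the two 4-(trifluoromethyl)phenyl compounds cannot be read, and their values are limits, not numbers: (the limit of > 10000 nM in this assay, at which 2 of the 4 values shown sit).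

Going by these compounds, it remains open whether the change also carries to a core with a methoxy group or a nitrile in place of the chloro or methyl. The compounds shown also leave open how an unsubstituted phenyl on the carbonyl carbon would compare.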